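A Tetrazolyl Sulfide Replaces the Oxazolyl Ether

A few compounds are considered here, and "the series" means these few. Any claim that something is new, unique, unknown or untested is made for them only; others in the source may bear on it.

Compound 1, `CCOC(=O)c1c(C)noc1OCC(=O)[C@H](CC(=O)O)NC(=O)[C@@H](NC(=O)COc1cccc2ccccc12)C(C)C`, is the starting point. In a functional assay on Jurkat cells (Homo sapiens) for inhibition (on this read-out higher numbers stand for weaker inhibition and lower numbers for stronger inhibition), compound 1 gives only a limit of the assay, > 200000 nM. Compound 2, `CC(C)[C@H](NC(=O)COc1cccc2ccccc12)C(=O)N[C@@H](CC(=O)O)C(=O)CSc1nc(-c2ccccc2)no1`, gives 102000 nM in this assay. Compound 3, `CC(C)[C@H](NC(=O)COc1cccc2ccccc12)C(=O)N[C@@H](CC(=O)O)C(=O)CSc1nncn1C`, again sits at a limit of the assay, > 200000 nM. The picture is dominated by the limit of > 200000 nM in this assay, at which 2 of the 3 values shown sit. The step to compound 4, `CC(C)[C@H](NC(=O)COc1cccc2ccccc12)C(=O)N[C@@H](CC(=O)O)C(=O)CSc1nnnn1-c1ccccc1`, is (1-phenyl-1H-tetrazol-5-yl)sulfanyl in place of (4-(ethoxycarbonyl)-3-methyl-1,2-oxazol-5-yl)oxy on a saturated chain carbon bound to a carbonyl carbon. The measured steps that bear on it are an at least 1.9-fold lower number from compound 1 to compound 2 (0.29 log units; that floor lies within the scatter) and a step that the two limits leave unreadable from compound 1 to compound 3; between the two sulfides there is an at least 1.9-fold higher number from compound 2 to compound 3 (0.29 log units; that floor lies within the scatter). None of these earlier replacements at this position gave a change clearly beyond the scatter, so compound 4 is expected to stay near the limit, with an expected step of an at least 1.3-fold lower number from compound 1 to compound 4 (0.12 log units; that floor lies within the scatter). Compound 4 is estimated at 150000 nM, between 60000 nM and 400000 nM.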

Compound 4, half-maximal inhibitory concentration: 153000 nM
The estimate for compound 4 lay 1.0-fold (0.01 log units) below the measured number; measured number inside the range.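

In this assay, the (1-phenyl-1H-tetrazol-5-yl)sulfanyl group gives a second readable number at this position, but changing the ring on the sulfur stays within the scatter, with a 1.5-fold higher number from compound 2 to compound 4 (0.18 log units; within the scatter). The steps from the two compounds held at a limit give only floors, an at least 1.3-fold lower number from compound 1 to compound 4 (0.11 log units; that floor lies within the scatter) and an at least 1.3-fold lower number from compound 3 to compound 4 (0.11 log units; that floor lies within the scatter), so neither shows a clear gain: the limit of > 200000 nM in this assay, at which 2 of the 4 values shown sit.

The compounds shown leave open whether a phenyl ring bearing an amine or a carboxylic acid would move the number beyond the scatter in this assay.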